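Exchanging the Aryl Group on the Ring Amine of Compound 1

The source may hold more compounds than are shown below. What is called first, only, known or untested is meant among the compounds shown, and "the series" means these compounds.

Measured so far:
compound 1, `Nc1scc(CN2CCN(c3cc(Cl)cc(Cl)c3)CC2)c1C(=O)c1ccc(Cl)cc1` — -74%
compound 2, `Nc1scc(CN2CCN(c3ccc(OC(F)(F)F)cc3)CC2)c1C(=O)c1ccc(Cl)cc1` — -74%

Compound 1 `Nc1scc(CN2CCN(c3cc(Cl)cc(Cl)c3)CC2)c1C(=O)c1ccc(Cl)cc1` and compound 2 `Nc1scc(CN2CCN(c3ccc(OC(F)(F)F)cc3)CC2)c1C(=O)c1ccc(Cl)cc1` share one core and differ only in the aryl group carried on an amine nitrogen in a ring. In a functional assay on CHO cells with adenosine receptor A1 (Homo sapiens) as the target, read by cAMP accumulation and immunoassay, with a stated time of 6 min, tested at 10 uM (on this read-out higher numbers stand for a weaker effect at the one concentration tested and lower numbers for a stronger effect), compound 1 gives -74%. In this assay compound 2 gives -74%. Compound 1 therefore stands level with compound 2 at the digits shown, and the step of no change at the digits printed from compound 1 to compound 2 (within the scatter) lies within the scatter, with 4-(trifluoromethoxy)phenyl in place of 3,5-dichlorophenyl on an amine nitrogen in a ring.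

Compound 3 `Nc1scc(CN2CCN(c3cccc(F)c3F)CC2)c1C(=O)c1ccc(Cl)cc1` differs from compound 1 in the same place: 2,3-difluorophenyl in place of 3,5-dichlorophenyl on an amine nitrogen in a ring. Among the compounds with values here, the only measured step that bears on this change is no change at the digits printed from compound 1 to compound 2 (within the scatter), which showed no change. On that basis the step of no change at the digits printed from compound 1 to compound 3 (within the scatter) is expected to be none beyond the scatter. Compound 3 is accordingly estimated at -74% in this assay, with a range from -90% to -55%.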

Compound 3, a percentage reported as activity, at one concentration (the size of the read-out at that concentration, not a potency): -79%
Estimate against measurement, compound 3: 5 percentage points above; the range from low to high includes it.
By their numbers in this assay, from the lowest: compounds 3, 1 and 2 (each within the scatter of the next).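

In this assay, a third aryl group on the ring amine again leaves the read-out within the scatter, with a number 5 percentage points lower from compound 1 to compound 3 (within the scatter) and a number 5 percentage points lower from compound 2 to compound 3 (within the scatter). Compound 1, compound 2 and compound 3 therefore cannot be told apart here, so 2,3-difluorophenyl now joins 3,5-dichlorophenyl and 4-(trifluoromethoxy)phenyl as an aryl group on this nitrogen that keeps the read-out at the same level, and the step from chlorine to fluorine as phenyl substituent adds no separation. Nothing available bears on why these three aryl groups read alike.

Going by these compounds, all three compounds carry a substituted phenyl on this nitrogen, so it remains open whether an unsubstituted phenyl, a pyridine ring or a simple methyl group would hold the same level. On these data alone, the read-out, taken at one concentration, is not a potency, and any differences in potency among the three also remain open.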